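A few compounds are considered here, and "the series" means these few. Any claim that something is new, unique, unknown or untested is made for them only; others in the source may bear on it.

Measured so far:
Compound 1 `Nc1nc(-c2ccc(F)cc2)cc(-c2ccc(C3NC(=O)c4ccccc4N3)cc2)n1`, for which an ADME assay on J774.A1 cells (Mus musculus) for cytotoxicity, read by MTT assay, with a stated time of 72 h (on this read-out lower numbers stand for higher toxicity in this test and higher numbers for lower toxicity in this test), gave "not determined" (no result reported).
Compound 2 `COc1cc(C(Nc2ccc(C3(C)NC(=O)c4ccccc4N3)cc2)c2nnnn2C(C)(C)C)cc(OC)c1OC`, for which this assay gave "not determined" (no result reported).
Compound 3 `CC1(c2ccc(Nc3nc(N4CCc5ccccc5C4)nc(N4CCc5ccccc5C4)n3)cc2)NC(=O)c2ccccc2N1`, for which this assay gave > 400000 nM; this is a limit of the test, not a number.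

Among the measured compounds shown here, compound 1 therefore stands without a number of its own in this assay, and the only reading among the three compounds is the limit of > 400000 nM in this assay, at which 1 of the 3 values shown sits. Compound 4 `COc1cccc(-c2cc(-c3ccc(C4NC(=O)c5ccccc5N4)cc3)nc(N)n2)c1OC` differs from compound 1 in one place: 2,3-dimethoxyphenyl in place of 4-fluorophenyl on an aromatic carbon. For the measured compounds named here, no measured pair shows what this change does, so no shift beyond the usual scatter is expected from it. Compound 4 is expected to give about 200000 nM in this assay, within the range 30000 nM to 600000 nM, with a fair chance that only a limit is reported.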

Compound 4, half-maximal cytotoxic concentration: > 400000 nM
Compound 4: only a limit was reported; the forecaster's own chance of this, stated with the estimate: 50%; middle value at least 2.0-fold (0.30 log units) from the limit.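

In this assay, among the compounds shown here, neither compound 1 nor compound 4 has a single number, so no step between them can be read. Compound 4 gives only a limit, not a number: the limit of > 400000 nM in this assay, at which 2 of the 4 values shown sit. Still open, going by these compounds, is whether 2,3-dimethoxyphenyl in place of 4-fluorophenyl changes the result in this assay at all.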